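A few compounds are considered here, and "the series" means these few. Any claim that something is new, unique, unknown or untested is made for them only; others in the source may bear on it.

compound 1 `CCCCCCCCCCc1cc2cn([C@H]3C[C@H](O)[C@@H](CO)O3)c(=O)nc2o1` gives > 510000 nM
compound 2 `Cc1ccc(CCc2cc3cn([C@H]4C[C@H](O)[C@@H](CO)O4)c(=O)nc3o2)cc1` gives > 540000 nM
compound 3 `CCCc1ccc(CCc2cc3cn([C@H]4C[C@H](O)[C@@H](CO)O4)c(=O)nc3o2)cc1` gives > 130000 nM

These readings come from an ADME assay on HEL cells (Homo sapiens) for cytotoxicity, with a stated time of 3 days (on this read-out lower numbers stand for higher toxicity in this test and higher numbers for lower toxicity in this test), and all three are limits, not exact numbers. Compound 3 stands at > 130000 nM as a limit, so it cannot be ranked against the other two compounds.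

Compound 4 `O=c1nc2oc(CCc3ccccc3)cc2cn1[C@H]1C[C@H](O)[C@@H](CO)O1` has not yet been measured. It differs from compound 3 by hydrogen in place of propyl on an aromatic carbon in one place: hydrogen in place of propyl on an aromatic carbon, para to a large group. This turns 4-propylphenyl into phenyl.

Among the compounds with values here, three measured steps bear on this change. The closest is a step that the two limits leave unreadable from compound 2 to compound 3 and it too alters the group on that ring, while a step that the two limits leave unreadable from compound 1 to compound 2 and a step that the two limits leave unreadable from compound 1 to compound 3 exchange octyl for a substituted phenyl. None of these steps has a readable size, so neither a size nor a direction can be carried over from them. In this assay no step beyond the usual scatter is expected for compound 4, and another limit is the most likely report. The expected change is a step that the limit leaves unreadable from compound 3 to compound 4 and it remains only an estimate. For compound 4 the estimated value is 500000 nM with 130000 nM to 600000 nM as the expected range.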

Compound 4, half-maximal cytotoxic concentration: > 560000 nM
Compound 4: only a limit was reported; the forecaster's own chance of this, stated with the estimate: 85%; at least 1.1-fold (0.04 log units) between middle value and limit.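

In this assay compound 4 is reported only as a limit, and compound 1, compound 2 and compound 3 are limits too; no step among these compounds can be read. The compounds shown leave open whether exchanging the group on the shared core changes toxicity in this test, and at what concentration any toxicity would appear.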